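This account rests on a few compounds, and the source may have more. Where it says the series, first, only, none or still open, it means among the compounds named here.

Working notes on the series. All three measured compounds share one core, seen in compound 1 `O=C(CSc1nnnn1-c1cccc2ccccc12)N/N=C/c1cccs1`, and differ only in the group on a carbon with a double bond to nitrogen. In an ADME assay on MT4 cells (Homo sapiens) for cytotoxicity, read by MTT assay (a higher number here means that more compound is tolerated, a lower number that less compound is tolerated), compound 1 gives > 316000 nM, which is a limit of the assay and not a number. Compound 2 `O=C(CSc1nnnn1-c1cccc2ccccc12)N/N=C/c1ccc(Cl)cc1` carries 4-chlorophenyl at that position; in this assay compound 2 gives > 295000 nM, again a limit. Compound 3 `O=C(CSc1nnnn1-c1cccc2ccccc12)N/N=C/c1ccc(F)cc1` carries 4-fluorophenyl; in this assay compound 3 gives > 307000 nM, also a limit. Accordingly the step that the two limits leave unreadable from compound 1 to compound 2 and the step that the two limits leave unreadable from compound 1 to compound 3 cannot be sized, both ends of each sitting at a limit, the limit of > 316000 nM in this assay, at which 1 of the 3 values shown sits, on one side and the limit of > 295000 nM in this assay, at which 1 of the 3 values shown sits, or the limit of > 307000 nM in this assay, at which 1 of the 3 values shown sits, on the other; the step that the two limits leave unreadable from compound 2 to compound 3 is likewise unreadable.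

Compound 4 `COc1cc(/C=N/NC(=O)CSc2nnnn2-c2cccc3ccccc23)ccc1O` differs from compound 1 by 4-hydroxy-3-methoxyphenyl in place of thiophen-2-yl on a carbon with a double bond to nitrogen. Each exchange of the thiophen-2-yl tried so far has left the read-out at a limit, so no step beyond the scatter is expected from compound 1 to compound 4, estimated as an at least 1.0-fold lower number from compound 1 to compound 4 (0.02 log units; that floor lies within the scatter). For compound 4 the expected value in this assay is 300000 nM, within 100000 nM to 600000 nM, most likely reported again only as a limit.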

Compound 4, half-maximal cytotoxic concentration: > 287000 nM
Compound 4 was reported as a limit; the forecaster's own chance of this, stated with the estimate: 80%; the middle value does not contradict the limit.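

In this assay compound 4 also sits at a limit, so its steps to compound 1, compound 2 and compound 3 cannot be read. The compounds shown leave open where any of the four reaches its half-maximal cytotoxic concentration, and whether the group on a carbon with a double bond to nitrogen changes that value at all.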